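The compounds below may be only part of what the source reports. "The series", "measured", "known", "first", "only" and "open" are said of these compounds alone.

Measured in an assay on HEK293 cells for inhibition of solute carrier family 22 member 12 (Homo sapiens), read by scintillation counting, with a stated time of 12 min; a higher number here means a weaker inhibitor, a lower number a stronger inhibitor:
compound 1 `O=C1COc2cccc(SC3(C(=O)O)CCC3)c2N1`: > 10000 nM; this is a limit of the assay, not a number
compound 2 `Nc1ccc2nccc(SC3(C(=O)O)CCC3)c2c1`: 1790 nM
compound 3 `O=C(O)C1(Sc2ccnc3ccc(-c4ccc(C(F)(F)F)cc4)cc23)CCC1`: 1750 nM

Compound 2 stands highest of the two numbers given, but compound 3 lies within the usual scatter of it, so no order between the two can be claimed. Compound 4 `O=C(O)C1(Sc2ccnc3ccc(-c4ccccc4F)cc23)CCC1` is not yet measured. Change from compound 2 to compound 4: 2-fluorophenyl in place of amino on an aromatic carbon. Within the data shown here, no step between measured compounds is available for this change. Compound 3, which also carries a phenyl ring bearing a trifluoromethyl group in place of the amino, gives 1750 nM, indistinguishable from compound 2. The step of a 1.2-fold lower number from compound 2 to compound 4 (0.08 log units; within the scatter) is therefore expected to be small, within or near the scatter. Compound 4 is estimated at 1500 nM, with a range of 500 nM to 4500 nM.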

Compound 4, half-maximal inhibitory concentration: 333 nM
For compound 4 the middle estimate is 4.5-fold (0.65 log units) above the measured one, and the stated range ends above it.
By their numbers in this assay, from the lowest: compound 4; then compounds 3 and 2 (each within the scatter of the next). At a limit, above all of these: compound 1.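

In this assay, among these compounds, 2-fluorophenyl in place of amino on this aromatic carbon gives a 5.4-fold lower number from compound 2 to compound 4 (0.73 log units; beyond the scatter), the first step beyond the scatter. The identity of the aryl group matters: compound 3, with a trifluoromethyl-bearing phenyl ring on that carbon, gives 1750 nM, whereas compound 4 gives 333 nM. No measurement shown accounts for this step. The compounds shown leave open whether the lower number depends on the fluorine, as an unsubstituted phenyl or a 2-chlorophenyl group on that carbon would test.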